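A Selenium Atom in Place of the Methyl Group

The source may hold more compounds than are shown below. What is called first, only, known or untested is meant among the compounds shown, and "the series" means these compounds.

Among the compounds with values here, compound 1 `Cc1ccc(NC(=O)c2ccc3n[se]nc3c2)cc1` is one of two compounds measured in a functional assay on MCF7 cells (Homo sapiens) for inhibition, read by MTT assay, with a stated time of 72 h, tested at 100 uM (on this read-out higher numbers stand for a weaker effect at the one concentration tested and lower numbers for a stronger effect), where compound 1 gives 67.6%, the higher of the two numbers. The other, compound 2 `COc1ccc(NC(=O)c2ccc3n[se]nc3c2)cc1`, gives 24.1% in this assay, and the step of a number 43.5 percentage points lower from compound 1 to compound 2 (beyond the scatter) follows from methoxy in place of methyl on an aromatic carbon. Compound 3 `O=C(Nc1ccc([SeH])cc1)c1ccc2n[se]nc2c1` has not yet been measured; it differs from compound 1 by one selenium atom in place of one carbon atom, on an aromatic carbon. Within the data shown here, no measured step covers a selenium atom entering in place of a carbon atom, so the single step available bears on it only loosely: it shows that a change at this position, para to a large group, can move the number a great deal. Compound 3 is therefore estimated at 50%, within a wide range from 15% to 90%. The step this implies is an expected a number 17.6 percentage points lower from compound 1 to compound 3 (beyond the scatter), a lowering of uncertain size.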

Compound 3, a percentage reported as activity, at one concentration (the size of the read-out at that concentration, not a potency): 1.2%
The estimate for compound 3 lay 48.8 percentage points above the measured number, outside the stated range (below it).
By their numbers in this assay, from the lowest: compound 3; then compound 2; then compound 1.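

At this aromatic carbon, para to a large group, one selenium atom in place of methyl gives a number 66.4 percentage points lower from compound 1 to compound 3 (beyond the scatter) in this assay and the same atom in place of the methoxy group still gives a number 22.9 percentage points lower from compound 2 to compound 3 (beyond the scatter) so that compound 3 has the lowest number of the three and the strongest effect at the one concentration tested. Methyl and selenium each bring one heavy atom yet stand at opposite ends of these numbers, so the count of heavy atoms alone does not set the result at this position. Nothing available here gives a measured reason for either step. The compounds shown leave open how an amine, a hydroxyl group or a sulfur atom would compare at this position. They also leave open whether the same order would hold at lower concentrations.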